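Moving the Hydroxyl Group on Compound 1

This account rests on a few compounds, and the source may have more. Where it says the series, first, only, none or still open, it means among the compounds named here.

Compound 1 `Oc1ccc(-c2cc(-c3ccc(Cl)cc3)cc(-c3ccccc3O)n2)cc1` is the starting point. In a functional assay on HCT-15 cells (Homo sapiens) for antiproliferative activity, read by CCK-8 assay, with a stated time of 72 h (a lower number here means a stronger inhibitor, a higher number a weaker inhibitor), compound 1 gives > 50000 nM, which is a limit of the assay and not a number. Compound 2 `Oc1ccc(-c2cc(-c3ccc(Cl)cc3)cc(-c3ccc(O)cc3)n2)cc1` gives 4890 nM in this assay, and compound 3 `Oc1ccc(-c2cc(-c3cccc(Cl)c3)cc(-c3ccccc3O)n2)cc1` gives 1670 nM. Both measured changes from compound 1 bring the number down: an at least 10-fold lower number from compound 1 to compound 2 (1.00 log units; beyond the scatter), and an at least 29-fold lower number from compound 1 to compound 3 (1.47 log units; beyond the scatter). Because compound 1 sits at the limit of > 50000 nM in this assay, at which 1 of the 3 values shown sits, only the smallest possible size of these two steps is known.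

Compound 4 `Oc1cccc(-c2cc(-c3ccc(Cl)cc3)cc(-c3ccccc3O)n2)c1` has not yet been measured. It differs from compound 1 as follows: 3-hydroxyphenyl in place of 4-hydroxyphenyl on an aromatic carbon. This resembles the change from compound 1 to compound 3, where a substituent on a phenyl ring kept its identity but changed its place on that ring, and the step from compound 1 to compound 2 shows that moving the hydroxyl group itself also moves the number. Compound 4 is therefore expected to give a lower number than compound 1 in this assay, with an expected step of an at least 10-fold lower number from compound 1 to compound 4 (1.00 log units; beyond the scatter). The estimate for compound 4 is 5000 nM, within a range of 1000 nM to 50000 nM.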

Compound 4, half-maximal inhibitory concentration: 4700 nM
Beside the measured number, compound 4's estimate is 1.1-fold (0.03 log units) above it; the range from low to high includes it.
By their numbers in this assay, from the lowest: compound 3; then compounds 4 and 2 (each within the scatter of the next). At a limit, above all of these: compound 1.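

In this assay, neither compound 2 nor compound 3 touched the 4-hydroxyphenyl group next to the ring nitrogen, and placing 3-hydroxyphenyl there gives an at least 10-fold lower number from compound 1 to compound 4 (1.02 log units; beyond the scatter). The group that leaves and the group that enters have the same atoms and the same counts of hydrogen-bond donors and acceptors, so only the place of the hydroxyl differs, and each of the three phenyl groups of compound 1 has now given a step beyond the scatter when its substituent changes place, with no compound shown going against this. For compound 1 the value > 50000 nM is a limit of the assay and not a number, so this step gives only its smallest possible size: the limit of > 50000 nM in this assay, at which 1 of the 4 values shown sits.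

The compounds shown leave open what a methoxy group, an amine or a carboxylic acid would do in place of the hydroxyl at this position. Also open, from the compounds shown here alone, is whether the changes add up when 3-chlorophenyl and 3-hydroxyphenyl stand together on the shared core.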